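The compounds below may be only part of what the source reports. "The series", "measured", "known", "first", "only" and "open" are said of these compounds alone.

Working notes on the series. The shared core carries a triazole on a side chain, and the four compounds differ in what sits on the triazole and in the linker. For the measured compounds named here, compound 1 `CC(C)(C)c1cn(C[C@H](O)[C@H]2OC(=O)C(OCc3ccccc3)=C2OCc2ccccc2)nn1` and compound 3 `C[Si](C)(C)c1cn(C[C@H](O)[C@H]2OC(=O)C(OCc3ccccc3)=C2OCc2ccccc2)nn1` bear small non-aromatic groups there; in a functional assay on SW-620 cells (Homo sapiens) for antiproliferative activity, read by MTT assay, with a stated time of 72 h (on this read-out lower numbers stand for stronger inhibition and higher numbers for weaker inhibition), compound 1 gives 35800 nM and compound 3 gives 56000 nM, and the single measured step, a 1.6-fold higher number from compound 1 to compound 3 (0.19 log units; within the scatter), replaces one four-atom group with another on the aromatic carbon. Compound 2 `COc1ccc(-c2cn(C/C=C3\OC(=O)C(OCc4ccccc4)=C3OCc3ccccc3)nn2)cc1` carries a 4-methoxyphenyl on the triazole together with an alkene linker. For compound 2 only a limit is known in this assay, > 100000 nM, and this is the limit of > 100000 nM in this assay, at which 1 of the 3 values shown sits. Compound 4 `O=C1O/C(=C\Cn2cc(-c3cccc(O)c3)nn2)C(OCc2ccccc2)=C1OCc1ccccc1` follows from compound 2 by the change (3-hydroxyphenyl in place of 4-methoxyphenyl on an aromatic carbon). Going by the values given here, no measured step involves an aryl group on the triazole or the alkene linker, so the only step available, the one within the scatter between compound 1 and compound 3, offers no direct guide. With compound 2 sitting at the limit, no step beyond the scatter is expected from compound 2 to compound 4; the expected step is a step that the limit leaves unreadable from compound 2 to compound 4. Compound 4 is therefore estimated at 120000 nM, within the range 40000 nM to 400000 nM, with a good chance that this assay again reports only a limit.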

Compound 4, half-maximal inhibitory concentration: 69800 nM
Beside the measured number, compound 4's estimate is 1.7-fold (0.24 log units) above it; low and high end bracket the measured number.
By their numbers in this assay, from the lowest: compounds 1, 3 and 4 (each within the scatter of the next). At a limit, above all of these: compound 2.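

In this assay compound 4 gives 69800 nM, so an aryl group on this aromatic carbon, together with the alkene linker, now has a measured number. For the compounds shown here, the change to 3-hydroxyphenyl in place of 4-methoxyphenyl comes with an at least 1.4-fold lower number from compound 2 to compound 4 (0.15 log units; that floor lies within the scatter), the first step that touches an aryl group at this place. Compound 2 stands at a limit, so this step gives only a floor and its true size cannot be read: the limit of > 100000 nM in this assay, at which 1 of the 4 values shown sits.

Still open, going by these compounds, is whether the step goes with the hydroxy group or with its place on the phenyl ring; 3-methoxyphenyl and 4-hydroxyphenyl on this carbon would separate the two. Also open, on these data alone, is how a 3-aminophenyl group on this carbon would read, and how 3-hydroxyphenyl would read on the hydroxy-bearing linker of compound 1 and compound 3, where only small non-aromatic groups stand so far.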